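The source may hold more compounds than are shown below. What is called first, only, known or untested is meant among the compounds shown, and "the series" means these compounds.

Measured in a functional assay on DU-145 cells (Homo sapiens) for inhibition, read by sulforhodamine B assay, with a stated time of 72 h; on this read-out lower numbers stand for stronger inhibition of growth and higher numbers for weaker inhibition of growth:
compound 1 `CC(C)(C)OC(=O)NCCCCCN1C(Nc2ccc(-c3ccccc3)cc2)=Nc2ccccc2C1CC(=O)NCc1ccccc1` gives 1790 nM
compound 2 `O=C(CC1c2ccccc2N=C(N2CCCCC2)N1c1ccccc1)NCc1ccc(NS(=O)(=O)c2ccc(F)cc2)cc1` gives 1710 nM

In this assay compound 2 and compound 1 sit within the scatter of each other, so neither can be set apart from the other on these two numbers. Compound 3 `CCN1C(N2CCCCC2)=Nc2ccccc2C1CC(=O)NCc1ccc(NS(=O)(=O)c2ccc(F)cc2)cc1` differs from compound 2 by ethyl in place of phenyl on an amine nitrogen in a ring. For the measured compounds named here, no measured pair shows this change, so its effect here is unknown; the expected step of a 1.5-fold higher number from compound 2 to compound 3 (0.16 log units; within the scatter) is a modest one, towards weaker inhibition or none beyond the scatter, with wide uncertainty. Compound 3 is estimated at 2500 nM, range 800 nM to 8000 nM.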

Compound 3, concentration for 50% growth inhibition: 17200 nM
Estimate against measurement, compound 3: 6.9-fold (0.84 log units) below, and the stated range ends below it.
By their numbers in this assay, from the lowest: compounds 2 and 1 (each within the scatter of the next); then compound 3.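

In this assay, the ring nitrogen next to the ring atom that bears the piperidin-1-yl group proves sensitive to its substituent: ethyl in place of phenyl gives a 10-fold higher number from compound 2 to compound 3 (1.00 log units; beyond the scatter). For the compounds shown here, this is the first pair that differs in one place, and growth inhibition here depends on which group sits on that nitrogen.

Going by these compounds, whether benzyl or cyclohexyl on this nitrogen would match compound 2 stays open, so the aromatic ring and the heavy-atom count cannot yet be separated. No measurement shown accounts for this step.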